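Chloro in Place of Methoxy in Compound 2

A few compounds are considered here, and "the series" means these few. Any claim that something is new, unique, unknown or untested is made for them only; others in the source may bear on it.

Compound 1 `CCOC(=O)c1c(-c2cccc(OC)c2)[nH]c2cc(OC)ccc2c1=O` gives > 22000 nM
Compound 2 `CCOC(=O)c1c(-c2cccc(OC)c2)[nH]c2cc(OC)c(OC)cc2c1=O` gives > 22000 nM
Compound 3 `CCOC(=O)c1c(-c2cccc(Oc3ccccc3)c2)[nH]c2cc(OC)c(OC)cc2c1=O` gives > 22000 nM

Compound 2 stands in an ADME assay on HEK293 cells (Homo sapiens) for cytotoxicity, read by luminescence, with a stated time of 72 h (on this read-out lower numbers stand for an effect already at smaller amounts and higher numbers for an effect only at larger amounts of compound), at > 22000 nM as a limit, not a number. Within the data shown here, the series so far shows the limit of > 22000 nM in this assay, at which 3 of the 3 values shown sit, and no measured number. The change to compound 4 `CCOC(=O)c1c(-c2cccc(OC)c2)[nH]c2cc(Cl)c(OC)cc2c1=O` is chloro in place of methoxy on an aromatic carbon, with chloro in place of methoxy on an aromatic carbon as its count. Bearing on it are a step that the two limits leave unreadable from compound 1 to compound 2 and a step that the two limits leave unreadable from compound 2 to compound 3 as the only measured steps, and neither has a readable size. No step beyond the scatter is therefore expected in this assay in either direction. The expected change is a step that the limit leaves unreadable from compound 2 to compound 4 as an estimate only. The estimate for compound 4 is 30000 nM with an expected range from 12000 nM to 60000 nM for this value.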

Compound 4, half-maximal effective concentration: > 22000 nM
Compound 4 ended at the assay's limit (the forecaster's own chance of this, stated with the estimate: 85%); the middle value is on the limit's open side.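

No step can be read between compound 2 and compound 4, as both end at a limit, not a number, in this assay: the limit of > 22000 nM in this assay, at which 4 of the 4 values shown sit.

The compounds shown leave open whether chloro in place of methoxy shifts the half-maximal effective concentration at all.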